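This account rests on a few compounds, and the source may have more. Where it says the series, first, only, none or still open, it means among the compounds named here.

Of the compounds shown here, three have so far been tested in a functional assay on MCF7 cells (Homo sapiens) for cytotoxicity, read by colorimetric assay and MTT assay; on this read-out higher numbers stand for weaker inhibition and lower numbers for stronger inhibition. Compound 1 `C=C1C(=O)O[C@@H]2[C@@H]1C[C@H](OC(C)=O)[C@](C)(O)CC/C=C(\C)CC/C=C(\C)[C@@H]2OC(C)=O` gives 10.3 ug/mL, the highest number of the three. Compound 2 `C=C1C(=O)O[C@H]2C[C@@]3(C)O[C@@H]3CC/C(C)=C/C[C@@H](OC(C)=O)/C(C)=C/C[C@H]12` gives 7.4 ug/mL, which lies within the usual scatter of the number for compound 1, so the two cannot be told apart. Compound 3 `C=C1C(=O)O[C@H]2C[C@]3(C)O[C@H]3CC/C(C)=C/CC/C(C)=C/C[C@H]12` gives 2.3 ug/mL, a number beyond the scatter below that of compound 1, so compound 3 inhibits more strongly than compound 1. Compound 4 `C=C1C(=O)O[C@@H]2[C@@H]1C[C@H](O)[C@](C)(O)CC/C=C(\C)CC/C=C(\C)[C@@H]2OC(C)=O` has not yet been measured. It differs from compound 1 in one place: hydrogen in place of acetyl on an oxygen on a saturated carbon. Going by the values given here, no measured pair shows what hydrogen in place of acetyl does here, so compound 4 is expected to stay close to compound 1, with the step of a 1.2-fold higher number from compound 1 to compound 4 (0.07 log units; within the scatter) within the scatter. Compound 4 is estimated at 12 ug/mL, between 5 ug/mL and 30 ug/mL.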

Compound 4, half-maximal inhibitory concentration: 8.9 ug/mL
Estimate against measurement, compound 4: 1.3-fold (0.13 log units) above; the range from low to high includes it.
By their numbers in this assay, from the lowest: compound 3; then compounds 2, 4 and 1 (each within the scatter of the next).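

In this assay, going by these compounds alone, the change from acetoxy to hydroxy, on an oxygen on a saturated carbon, gives a 1.2-fold lower number from compound 1 to compound 4 (0.06 log units; within the scatter) as the first measured single-place step. On the core of compound 1, the acetyl at this position can therefore be lost with no change that this read-out can distinguish from scatter. Nothing measured here offers an explanation for this result.

On these data alone, whether a benzoyl ester or an amine at this position would leave the number equally unchanged stays open. So does whether the other acetoxy group of compound 1 could also become hydroxy without a clear change.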